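A few compounds are considered here, and "the series" means these few. Any claim that something is new, unique, unknown or untested is made for them only; others in the source may bear on it.

In a functional assay on WI-38 VA13 cells (Homo sapiens) for cytotoxicity (on this read-out lower numbers stand for an effect already at smaller amounts and higher numbers for an effect only at larger amounts of compound), compound 3 `COC(=O)Nc1nc2ccc(NC(=O)c3c(Cl)cccc3Cl)cc2s1` stands at 0.0095 ug/mL and compound 1 `O=C(Nc1ccc2nc(NC(=O)C3CCC3)sc2c1)c1c(Cl)cccc1Cl` at 0.013 ug/mL within the scatter of each other. Compound 2 `O=C(O)CCC(=O)Nc1nc2ccc(NC(=O)c3c(Cl)cccc3Cl)cc2s1` gives > 6.6 ug/mL as a limit and not a number. Compound 4 `CC(C)OC(=O)Nc1nc2ccc(NC(=O)c3c(Cl)cccc3Cl)cc2s1` differs from compound 3 as isopropyl in place of methyl on an oxygen next to a carbonyl group with isopropyl in place of methyl on an oxygen next to a carbonyl group. The closest guide is a 1.4-fold lower number from compound 1 to compound 3 (0.14 log units; within the scatter) at the carbonyl carbon, a step within the scatter. The large at least 690-fold lower number from compound 2 to compound 3 (2.84 log units; beyond the scatter) came with the 2-carboxyethyl group, which compound 4 does not carry. No step beyond the scatter is therefore expected in this assay and the estimate is a 1.5-fold higher number from compound 3 to compound 4 (0.17 log units; within the scatter) for this change. For compound 4 an estimated 0.014 ug/mL is expected (range 0.005 ug/mL to 0.05 ug/mL).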

Compound 4, half-maximal effective concentration: 0.0026 ug/mL
Compound 4: middle estimate off by 5.4-fold (0.73 log units), on the high side, and the stated range ends above it.
By their numbers in this assay, from the lowest: compound 4; then compounds 3 and 1 (each within the scatter of the next). At a limit, above all of these: compound 2.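

In this assay, isopropyl in place of methyl on an oxygen next to a carbonyl group gives a step beyond the scatter, a 3.7-fold lower number from compound 3 to compound 4 (0.56 log units; beyond the scatter), so this position is not flat across small alkyl groups. Isopropoxy on the carbonyl carbon also separates from cyclobutyl, a 5.0-fold lower number from compound 1 to compound 4 (0.70 log units; beyond the scatter), which methoxy did not do. Compound 2 remains a limit and not a number, so an at least 2500-fold lower number from compound 2 to compound 4 (3.40 log units; beyond the scatter) is only a bound: the limit of > 6.6 ug/mL in this assay, at which 1 of the 4 values shown sits.

From the compounds shown here alone, whether a longer chain or a benzyl group on this oxygen extends the step remains open. So does whether an amine on the chain behaves like the carboxylic acid of compound 2.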